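The source may report more compounds than this note shows. Statements on the series, on what has been measured and on what is new or still open speak of the compounds shown alone.

In a functional assay on HCT-116 cells (Homo sapiens) for inhibition, read by MTT assay, with a stated time of 72 h (on this read-out higher numbers stand for weaker inhibition and lower numbers for stronger inhibition), three compounds sharing one core have been measured: compound 1 `O=C1/C(=C\c2ccccc2)c2c(ncn2COCc2ccccc2)CCN1Cc1ccc(F)cc1` gives 11200 nM, compound 2 `Cc1cccc(CN2CCc3ncn(COCc4ccccc4)c3/C(=C/c3ccccc3)C2=O)c1` gives 3800 nM, and compound 3 `COc1ccc(CN2CCc3ncn(COCc4ccccc4)c3/C(=C/c3ccccc3)C2=O)cc1` gives 31100 nM. Compound 3 thus has the highest number of the three, meaning the weakest inhibition. Compound 4 `O=C1/C(=C\c2ccccc2)c2c(ncn2COCc2ccccc2)CCN1Cc1ccc2ccccc2c1` differs from it in one place: naphthalen-2-yl in place of 4-methoxyphenyl on a saturated chain carbon bound to an amide-type nitrogen in a ring. Among the measured compounds shown here, only three groups at this place have been compared, and none is naphthalen-2-yl. Both steps leading to compound 3 raise the number: a 2.8-fold higher number from compound 1 to compound 3 (0.44 log units; beyond the scatter), and an 8.2-fold higher number from compound 2 to compound 3 (0.91 log units; beyond the scatter). The remaining step, a 2.9-fold lower number from compound 1 to compound 2 (0.47 log units; beyond the scatter), shows the spread between the other two groups. In this assay, a modest fall is therefore expected, a 3.5-fold lower number from compound 3 to compound 4 (0.54 log units; beyond the scatter). For compound 4, the estimated value is 9000 nM, within an expected range of 3000 nM to 30000 nM.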

Compound 4, half-maximal inhibitory concentration: 19400 nM
The estimate for compound 4 lay 2.2-fold (0.33 log units) below the measured number, within the range that was stated.
By their numbers in this assay, from the lowest: compound 2; then compounds 1, 4 and 3 (each within the scatter of the next, the first and the last beyond it).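

In this assay, naphthalen-2-yl, with 2 six-membered aromatic rings of carbon only, cannot be told apart from 4-methoxyphenyl (a 1.6-fold lower number from compound 3 to compound 4 (0.20 log units; within the scatter)) or from 4-fluorophenyl (a 1.7-fold higher number from compound 1 to compound 4 (0.24 log units; within the scatter)). The 3-methylphenyl group alone stands apart (a 5.1-fold higher number from compound 2 to compound 4 (0.71 log units; beyond the scatter)), so compound 2 keeps the lowest number of the four, and a second aromatic ring at this place brings no gain over it. Nothing available explains these differences.

Going by these compounds, all four groups are aromatic, so it remains open how a cyclohexyl group would compare here. Also open, on these data alone, is whether an amine or a carboxylic acid on the aromatic ring, or a longer chain leading to it, would bring the number below that of compound 2.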